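The source may report more compounds than this note shows. Statements on the series, on what has been measured and on what is new or still open speak of the compounds shown alone.

Of the compounds shown here, two have been measured in an assay on microsomes from intestine for inhibition of acyl-CoA:cholesterol acyltransferase (Oryctolagus cuniculus); on this read-out higher numbers stand for weaker inhibition and lower numbers for stronger inhibition. Compound 1, `Cc1cc(C)c(NC(=O)N(Cc2ccc(-c3ccccc3)nc2)C2CCCCCC2)c(C)c1`, gives 260 nM in this assay. Going by the values given here, compound 2, `Cc1cc(C)c(NC(=O)N(Cc2ccc(N3CCN(C)CC3)cc2)C2CCCCCC2)c(C)c1`, gives 57 nM in this assay, the lowest of the two numbers; its only neighbour is compound 1, whose number is higher by a gap that lies beyond the usual scatter. The two structures differ in more than one place, so their values alone cannot be tied to a single change.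

Compound 3, `Cc1cc(C)c(NC(=O)N(Cc2ccc(-n3ccnn3)cc2)C2CCCCCC2)c(C)c1`, has not yet been measured. It differs from compound 2 in one place: 1H-1,2,3-triazol-1-yl in place of 4-methylpiperazin-1-yl on an aromatic carbon. A six-membered non-aromatic ring leaves and a five-membered aromatic ring enters, on the same aromatic carbon.

Among the compounds with values here, no measured pair in this assay shows a change of this kind, so there is no precedent for its size. Compound 3 is expected to give a slightly higher number than compound 2, a step of a 2.1-fold higher number from compound 2 to compound 3 (0.32 log units; beyond the scatter), close to the edge of the usual scatter. The estimate for compound 3 in this assay is 120 nM, with a range from 30 nM to 500 nM.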

Compound 3, half-maximal inhibitory concentration: 42 nM
Beside the measured number, compound 3's estimate is 2.9-fold (0.46 log units) above it; low and high end bracket the measured number.
By their numbers in this assay, from the lowest: compounds 3 and 2 (each within the scatter of the next); then compound 1.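

In this assay, the change at this position gives a 1.4-fold lower number from compound 2 to compound 3 (0.13 log units; within the scatter), so the two compounds cannot be told apart on this read-out. Going by these compounds alone, this is the first single-place comparison in the set, and it shows that, at the aromatic carbon para to a large group, 4-methylpiperazin-1-yl can be swapped for 1H-1,2,3-triazol-1-yl, a smaller five-membered aromatic ring, without a measurable shift in the number. Nothing available explains why these two different rings read alike.

The compounds shown leave open whether any ring is needed at this carbon, or whether a plain hydrogen, a methoxy group or an open-chain dimethylamino group would serve as well. They also leave open how a carboxylic acid would read here.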